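Lengthening the aryl alkyl chain of the phenethyl ureas

The source may report more compounds than this note shows. Statements on the series, on what has been measured and on what is new or still open speak of the compounds shown alone.

Compound 1, `Cc1ccc(NC(=O)N[C@H](C)c2ccccc2)cc1`, in an ADME assay on the whole organism with Oryza sativa as the target, tested at 10 uM; on this read-out higher numbers stand for a weaker effect at the one concentration tested and lower numbers for a stronger effect: 64%
Compound 2, `CC(C)c1ccc(NC(=O)N[C@H](C)c2ccccc2)cc1`, this assay: 49%
Compound 3, `CCCCc1ccc(NC(=O)N[C@H](C)c2ccccc2)cc1`, this assay: 28%

Compound 3 gives the lowest of the three numbers. The steps leading to it are a number 36 percentage points lower from compound 1 to compound 3 (beyond the scatter) and a number 21 percentage points lower from compound 2 to compound 3 (beyond the scatter), and the step of a number 15 percentage points lower from compound 1 to compound 2 (beyond the scatter) runs the same way. Compound 4, `CCCCCCc1ccc(NC(=O)N[C@H](C)c2ccccc2)cc1`, carries the change (ethyl in place of hydrogen on a saturated chain carbon, four bonds along the chain from an aromatic carbon). Each longer chain on the aromatic carbon has so far gone with a lower number, with no compound going against that among these three. A further downward step is therefore expected, a number 13 percentage points lower from compound 3 to compound 4 (beyond the scatter), though smaller than the earlier ones because compound 3 gives 28% already. Compound 4 is expected at 15%, between 3% and 35%.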

Compound 4, a percentage reported as activity, at one concentration (the size of the read-out at that concentration, not a potency): 101%
Estimate against measurement, compound 4: 86 percentage points below, outside the stated range (above it).
By their numbers in this assay, from the lowest: compound 3; then compound 2; then compound 1; then compound 4.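

In this assay the downward run with chain length does not hold at this position: ethyl in place of hydrogen, four bonds along the chain from an aromatic carbon, gives a number 73 percentage points higher from compound 3 to compound 4 (beyond the scatter). The reversal also carries past both shorter-chain compounds, with a number 52 percentage points higher from compound 2 to compound 4 (beyond the scatter) and a number 37 percentage points higher from compound 1 to compound 4 (beyond the scatter), so the hexyl chain gives the highest number of the four, not the lowest. Nothing available accounts for this reversal. As far as these compounds go, what stays open is whether a pentyl chain would fall on the low or the high side of this turn, and whether an octyl chain would keep the number as high.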